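This account rests on a few compounds, and the source may have more. Where it says the series, first, only, none or still open, it means among the compounds named here.

Measured in an assay on HEK293 cells for positive allosteric modulation of metabotropic glutamate receptor 2 (Rattus norvegicus), read by thallium flux, with a stated time of 2.5 min; on this read-out lower numbers stand for smaller maximal responses and higher numbers for larger maximal responses:
compound 1, `Cc1c(OCCCCOCOc2ccc(C(=O)O)cc2)ccc(C(=O)CC2CCCC2)c1O`, 95.4%
compound 2, `Cc1c(OCCCCOc2ccc(C(=O)O)cc2F)ccc(C(=O)CC2CCCC2)c1O`, 83.8%
compound 3, `Cc1c(OCCCCOc2ccc(C(=O)O)cc2F)ccc(C(=O)CC(C)C)c1O`, 85%

Compound 2 stands lowest of the three numbers. Going by the values given here, compound 3 lies within the scatter of it, whereas the step of a number 11.6 percentage points lower from compound 1 to compound 2 (beyond the scatter) lies beyond the scatter, so compound 1 is the only measured compound clearly apart from compound 2.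

Compound 4, `Cc1c(OCCCCOc2cccc(C(=O)O)c2)ccc(C(=O)CC2CCCC2)c1O`, is not yet measured. It differs from compound 2 in one place:
3-carboxyphenyl in place of 4-carboxy-2-fluorophenyl on an oxygen on a saturated carbon

Of the measured steps, only a number 11.6 percentage points lower from compound 1 to compound 2 (beyond the scatter) concerns the group on an oxygen on a saturated carbon, and that step was modest. The step of a number 1.2 percentage points higher from compound 2 to compound 3 (within the scatter) concerns the other end of the molecule and was within the scatter, so it does not bear here. Among the compounds with values here, no measured pair shows the exchange of 4-carboxy-2-fluorophenyl for 3-carboxyphenyl itself; the one comparable step suggests at most a modest shift in either direction, and no step beyond the scatter is expected with confidence. The estimated step is a number 1.2 percentage points higher from compound 2 to compound 4 (within the scatter). Compound 4 is expected at 85%, with a range from 70% to 100%.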

Compound 4, largest response reached (reported as percent of maximum), in percent of the reference or control that the assay uses: 80.6%
Compound 4: middle estimate off by 4.4 percentage points, on the high side, within the range that was stated.
By their numbers in this assay, from the lowest: compounds 4, 2 and 3 (each within the scatter of the next); then compound 1.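

In this assay, the exchange at the group on an oxygen on a saturated carbon gives a number 3.2 percentage points lower from compound 2 to compound 4 (within the scatter), so a 3-carboxyphenyl group and a 4-carboxy-2-fluorophenyl group cannot be told apart at this place on this read-out. The same place also gives a number 14.8 percentage points lower from compound 1 to compound 4 (beyond the scatter), which leaves compound 1, with its (4-carboxyphenoxy)methyl group, apart from both compound 2 and compound 4, while the step between those two stays small. No supporting data bear on the origin of either step.

The exchange in compound 4 removes the fluorine and changes the carboxy group's numbered place together, so the share of each remains unresolved. A plain 4-carboxyphenyl group would separate the two, and a primary amide or tetrazole in place of the carboxylic acid would test whether that acid is needed at all.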